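The source may hold more compounds than are shown below. What is called first, only, known or untested is meant among the compounds shown, and "the series" means these compounds.

Measured so far, in a functional assay on A549 cells (Homo sapiens) for antiproliferative activity, read by MTT assay, with a stated time of 48 h; on this read-out lower numbers stand for stronger inhibition and higher numbers for weaker inhibition:

Compound 1, `CN(C)CCn1c(N)c(-c2nc3cc(Cl)ccc3[nH]2)c2nc(C#N)c(C#N)nc21`: in this assay compound 1 gives > 50000 nM, which is a limit of the assay, not a number.
Compound 2, `CCN(CC)CCn1c(N)c(-c2nc3cc(Cl)ccc3[nH]2)c2nc(C#N)c(C#N)nc21`: in this assay compound 2 gives > 50000 nM, again a limit rather than a number.
Compound 3, `CN(C)CCCCn1c(-c2c(N)n(C)c3nc(C#N)c(C#N)nc23)nc2ccccc21`: in this assay compound 3 gives 11200 nM.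

Compound 1 and compound 2 share one core and differ only by diethylamino in place of dimethylamino on a saturated chain carbon, two bonds along the chain from an aromatic nitrogen. Going by the values given here, both sit at the limit of > 50000 nM in this assay, at which 2 of the 3 values shown sit, so the step that the two limits leave unreadable from compound 1 to compound 2 cannot be read in either direction; it shows only that neither compound reaches a measurable number.

Compound 3 has a different core, and the difference between the two cores is not broken down here. Compound 4, `CCN(CC)CCCCn1c(-c2c(N)n(C)c3nc(C#N)c(C#N)nc23)nc2ccccc21`, is still unmeasured. It differs from compound 3 by diethylamino in place of dimethylamino on a saturated chain carbon, four bonds along the chain from an aromatic nitrogen. This is the same kind of change as that from compound 1 to compound 2, but the place is not the same: there the amine sat two bonds along the chain from an aromatic nitrogen, here it sits four bonds along. Since the earlier pair gives no readable step, the expectation rests on the smallness of the change alone. The step of a 1.1-fold higher number from compound 3 to compound 4 (0.03 log units; within the scatter) is expected to stay within the usual scatter, so compound 4 is estimated at 12000 nM, between 4000 nM and 40000 nM.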

Compound 4, half-maximal inhibitory concentration: 13100 nM
Estimate against measurement, compound 4: 1.1-fold (0.04 log units) below; measured number inside the range.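

On the core that carries the amine four bonds along the chain from an aromatic nitrogen, diethylamino in place of dimethylamino gives, in this assay, a 1.2-fold higher number from compound 3 to compound 4 (0.07 log units; within the scatter), so on this core the change makes no difference that this read-out can separate from scatter. On the other core, where the amine sits two bonds along the chain, the same change cannot be read, since both of its compounds stand at a limit of the assay and not at a number: the limit of > 50000 nM in this assay, at which 2 of the 4 values shown sit. Going by these compounds alone, the result therefore shows that the change is tolerated on one core, but it does not show that the change behaves alike on both, as only one readable step exists.

The compounds shown leave open whether a ring amine such as morpholine or piperidine at the end of the chain, or a longer chain, would move the number on the core of compound 3 beyond the scatter. As far as these compounds go, a carboxylic acid in place of the amine is equally open.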